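The source may report more compounds than this note shows. Statements on the series, on what has been measured and on what is new or still open speak of the compounds shown alone.

Compound 3 `O=C(Nc1ccc(-n2ncc3c(F)cccc32)cc1)Nc1ccc(Cl)c(C(F)(F)F)c1` gives 16000 nM in a functional assay on Bel-7402 cells (Homo sapiens) for cytotoxicity, read by MTT assay, with a stated time of 72 h; on this read-out lower numbers stand for stronger inhibition and higher numbers for weaker inhibition. That places it level with compound 1 `O=C(Nc1ccc(-n2ncc3c(C(F)(F)F)cccc32)cc1)Nc1ccc(Cl)c(C(F)(F)F)c1`, which gives 16000 nM; together these are the highest of the three numbers. Among the compounds with values here, compound 2 `O=C(Nc1ccc(-n2ncc3c(Br)cccc32)cc1)Nc1ccc(Cl)c(C(F)(F)F)c1` gives 1300 nM, and the move from it, a 12-fold higher number from compound 2 to compound 3 (1.09 log units; beyond the scatter), is the only large step in this small set. Compound 4 `COc1cccc2c1cnn2-c1ccc(NC(=O)Nc2ccc(Cl)c(C(F)(F)F)c2)cc1` differs from compound 3 in one place: methoxy in place of fluoro on an aromatic carbon. Within the data shown here, no measured step involves a methoxy group, so the guidance is indirect: no change at the digits printed from compound 1 to compound 3 (within the scatter) and a 12-fold higher number from compound 2 to compound 3 (1.09 log units; beyond the scatter) show that a swap at that spot can pass unnoticed or move the number a long way. Without closer precedent, compound 4 is expected to give 8000 nM, within 2000 nM to 30000 nM, an expected step of a 2.0-fold lower number from compound 3 to compound 4 (0.30 log units; within the scatter).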

Compound 4, half-maximal inhibitory concentration: 2900 nM
For compound 4 the middle estimate is 2.8-fold (0.44 log units) above the measured one; measured number inside the range.
By their numbers in this assay, from the lowest: compound 2; then compound 4; then compounds 1 and 3 (each within the scatter of the next).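

In this assay, methoxy opens a middle level at this position: a 5.5-fold lower number from compound 3 to compound 4 (0.74 log units; beyond the scatter) and a 5.5-fold lower number from compound 1 to compound 4 (0.74 log units; beyond the scatter), yet a 2.2-fold higher number from compound 2 to compound 4 (0.35 log units; beyond the scatter). The earlier compounds shown here showed only a low bromo level and a high level shared by fluoro and trifluoromethyl, so this position is not a simple two-level switch. Nothing available here explains this order of the groups. From the compounds shown here alone, whether an amine, a nitrile or a longer chain such as ethoxy would match bromo or surpass it remains open.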